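A few compounds are considered here, and "the series" means these few. Any claim that something is new, unique, unknown or untested is made for them only; others in the source may bear on it.

Compound 1 `Fc1ccc(/C=N/c2sc3c(c2-c2nc4ccccc4s2)CCC3)cc1` and compound 2 `Fc1ccc(/C=N/c2sc3c(c2-c2nc4ccccc4s2)CCCC3)cc1` share one core and differ from each other only within it. In an ADME assay on HepG2 cells (Homo sapiens) for cytotoxicity, read by MTT assay, with a stated time of 72 h (on this read-out higher numbers stand for lower toxicity in this test and lower numbers for higher toxicity in this test), compound 1 gives 302 ug/mL and compound 2 gives 324 ug/mL; compound 2 thus shows the larger of the two numbers, yet the gap to compound 1 is within the scatter, so the pair reads as equal. Compound 3 `Fc1ccccc1/C=N/c1sc2c(c1-c1nc3ccccc3s1)CCCC2` differs from compound 2 by 2-fluorophenyl in place of 4-fluorophenyl on a carbon with a double bond to nitrogen. Within the data shown here, no measured pair shows what such a shift does here. The step of a 1.1-fold lower number from compound 2 to compound 3 (0.03 log units; within the scatter) is expected to stay within the scatter, in no set direction. Compound 3 is therefore estimated at 300 ug/mL, ranging from 150 ug/mL to 600 ug/mL.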

Compound 3, half-maximal cytotoxic concentration: 398 ug/mL
Beside the measured number, compound 3's estimate is 1.3-fold (0.12 log units) below it, within the range that was stated.
By their numbers in this assay, from the lowest: compounds 1, 2 and 3 (each within the scatter of the next).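

Putting 2-fluorophenyl in place of 4-fluorophenyl on a carbon with a double bond to nitrogen, a place where compound 1 and compound 2 do not differ, gives a 1.2-fold higher number from compound 2 to compound 3 (0.09 log units; within the scatter) in this assay, so the pair reads as equal. For this pair, then, the place of the fluorine on the phenyl ring does not separate the numbers. Nothing available offers an account of this result. As far as these compounds go, whether an amine or a carboxylic acid in place of the fluorine would give a step beyond the scatter remains open. So does whether 2-fluorophenyl reads the same way on the core of compound 1.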